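A few compounds are considered here, and "the series" means these few. Any claim that something is new, unique, unknown or untested is made for them only; others in the source may bear on it.

Working notes on the series. Going by the values given here, in a functional assay on MGC-803 cells (Homo sapiens) for inhibition, read by MTT assay, with a stated time of 72 h (a lower number here means a stronger inhibitor, a higher number a weaker inhibitor), compound 3 `O=C(/C=C/c1cc([N+](=O)[O-])ccc1Cl)/C=C/c1ccccc1Oc1ncnc2ccc(Cl)cc12` gives 1960 nM, the lowest of the three numbers so far. Compound 1 `O=C(/C=C/c1ccc(Oc2ncnc3ccc(Cl)cc23)cc1)/C=C/c1cc([N+](=O)[O-])ccc1Cl` gives 2150 nM, a value within the scatter of compound 3, so no order between the two is claimed. Among the compounds with values here, compound 2 `O=C(/C=C/c1ccc(Cl)c([N+](=O)[O-])c1)/C=C/c1ccccc1Oc1ncnc2ccc(Cl)cc12` gives 5320 nM, and the step of a 2.7-fold lower number from compound 2 to compound 3 (0.43 log units; beyond the scatter) is the only measured step in the set; it involves the same ring as the change now considered but only rearranges its substituents.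

Compound 4 `O=C(/C=C/c1ccc(Cl)c(Cl)c1)/C=C/c1ccccc1Oc1ncnc2ccc(Cl)cc12` differs from compound 3 as follows: 3,4-dichlorophenyl in place of 2-chloro-5-nitrophenyl on a double-bonded chain carbon bound to a double-bonded chain carbon. Within the data shown here, no measured step covers an exchange of a nitro group for a chlorine, so the direction cannot be read from the data. The step from compound 2 to compound 3 shows that this ring tolerates modest change without a large shift in this assay, and a step of similar or smaller size is expected here, with no preferred direction beyond the scatter. Compound 4 is therefore estimated at 2600 nM, within 1000 nM to 7000 nM, an expected step of a 1.3-fold higher number from compound 3 to compound 4 (0.12 log units; within the scatter).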

Compound 4, half-maximal inhibitory concentration: 16200 nM
Estimate against measurement, compound 4: 6.2-fold (0.79 log units) below; the measured number lies above the stated range.
By their numbers in this assay, from the lowest: compounds 3 and 1 (each within the scatter of the next); then compound 2; then compound 4.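

Within the three compounds sharing the core of compound 3, chloro in place of nitro on an aromatic carbon now has a direct reading in this assay as a 3.0-fold higher number from compound 2 to compound 4 (0.48 log units; beyond the scatter) and the full ring exchange reads as an 8.3-fold higher number from compound 3 to compound 4 (0.92 log units; beyond the scatter) with both steps beyond the scatter. The ring on this double-bonded chain carbon is therefore not indifferent to the change, and 3,4-dichlorophenyl gives a higher number than either nitro-bearing ring, with no compound shown going against this. Nothing measured here explains the shift.

The compounds shown leave open whether the same exchange would read alike on the core of compound 1. They also leave open how a ring carrying an amine or a carboxylic acid in place of the nitro group would stand.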